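A few compounds are considered here, and "the series" means these few. Any claim that something is new, unique, unknown or untested is made for them only; others in the source may bear on it.

Of the compounds shown here, three that share one core have been tested in a functional assay on MOLT-3 cells (Homo sapiens) for cytotoxicity, read by MTT assay, with a stated time of 72 h; a higher number here means a weaker inhibitor, a lower number a stronger inhibitor. Compound 1 `CC(=O)O[C@H](C/C(C)=C/CO)[C@@]1(C)[C@H](C)CC=C2[C@@H]1CCCC2(C)C` gives only a limit of the assay there, > 30000 nM. Compound 2 `C/C(=C\COC(=O)c1ccccc1)C[C@@H](O)[C@@]1(C)[C@H](C)CC=C2[C@@H]1CCCC2(C)C` likewise gives only a limit, > 30000 nM. Compound 3 `COC(=O)/C=C(\C)C[C@@H](OC(C)=O)[C@@]1(C)[C@H](C)CC=C2[C@@H]1CCCC2(C)C` also gives only a limit, > 30000 nM. Compound 3 therefore stands exactly where compounds 1 and 2 stand, at the edge of what the assay can report, without a number of its own. Among the measured compounds shown here, the single step between measured compounds that differ in one place, a step that the two limits leave unreadable from compound 1 to compound 3, has no readable size because both of its ends are limits (the limit of > 30000 nM in this assay, at which 3 of the 3 values shown sit).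

Compound 4 `CC(=O)O[C@H](C/C(C)=C/C(=O)O)[C@@]1(C)[C@H](C)CC=C2[C@@H]1CCCC2(C)C` differs from compound 3 in one place: hydrogen in place of methyl on an oxygen next to a carbonyl group. For the measured compounds named here, no measured step touches this particular change, and the one step available, a step that the two limits leave unreadable from compound 1 to compound 3, offers no size to lean on. Since every measured value sits at the same limit (the limit of > 30000 nM in this assay, at which 3 of the 3 values shown sit), nothing in the numbers points to a step in this assay in either direction beyond the scatter. Compound 4 is therefore expected to give about 40000 nM in this assay, within a range from 15000 nM to 100000 nM. The step this estimate means, a step that the limit leaves unreadable from compound 3 to compound 4, is expected to stay within the scatter, most likely again as a limit rather than a number.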

Compound 4, half-maximal inhibitory concentration: > 30000 nM
Compound 4: no number, only a limit (the forecaster's own chance of this, stated with the estimate: 85%); the middle value lies beyond the limit too.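

Compound 4 also gives only a limit, > 30000 nM. The steps from compound 3 to compound 4 and from compound 1 to compound 4 therefore cannot be read, because both ends of each are limits: the limit of > 30000 nM in this assay, at which 4 of the 4 values shown sit.

The compounds shown leave open how large these steps are, and whether any change on the shared core would give a measurable value in this assay.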